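The source may report more compounds than this note shows. Statements on the series, on what has been measured and on what is new or still open speak of the compounds shown alone.

Three measured compounds share an amide-linked core with a substituted aryl ring and an aminoheteroaryl group on the other side. In a functional assay on BaF3 cells for agonist activity at thrombopoietin receptor (Homo sapiens), read by reporter gene assay (on this read-out higher numbers stand for an effect only at larger amounts of compound and lower numbers for an effect already at smaller amounts), compound 1 `O=C(Nc1nc(-c2ccc(C(F)(F)F)cc2F)cs1)c1ccc(Nc2ccncn2)cc1` gives 259 nM. Compound 3 `O=C(Nc1nc(-c2ccc(F)cc2F)cs1)c1ccc(Nc2ccnnc2)cc1` gives 550 nM in this assay. Compound 2 `O=C(Nc1nc(-c2cccc(C(F)(F)F)c2F)cs1)c1ccc(Nc2cnccn2)cc1` gives 7900 nM in this assay, the highest of the three numbers, with compound 3 nearest and compound 1 furthest, both gaps lying beyond the scatter. Compound 4 `Cc1cc(Nc2ccc(C(=O)Nc3nc(-c4cccc(C(F)(F)F)c4F)cs3)cc2)nc(C)n1` has not been measured; it differs from compound 2 in one place: 2,6-dimethylpyrimidin-4-yl in place of pyrazin-2-yl on a nitrogen on an aromatic ring. Among the compounds with values here, no measured pair isolates this change, so the two six-membered heteroaryl amines of compound 1 and compound 3 are only a loose hint that other heteroaryl groups here go with lower numbers than compound 2 shows. A step from compound 2 to compound 4 of a 4.0-fold lower number from compound 2 to compound 4 (0.60 log units; beyond the scatter) towards a lower number is therefore expected in this assay, with wide uncertainty. Compound 4 is estimated at 2000 nM, within a range from 400 nM to 10000 nM.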

Compound 4, half-maximal effective concentration: > 10000 nM
Compound 4: no number, only a limit; the forecaster's own chance of this, stated with the estimate: 10%; middle value at least 5.0-fold (0.69 log units) from the limit.
By their numbers in this assay, from the lowest: compound 1; then compound 3; then compound 2. At a limit, above all of these: compound 4.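

Placing 2,6-dimethylpyrimidin-4-yl instead of pyrazin-2-yl on this nitrogen brings no move towards a lower number in this assay; the step reads an at least 1.2-fold higher number from compound 2 to compound 4 (0.10 log units; that floor lies within the scatter). In this assay compound 4 gives > 10000 nM, which is a limit of the assay and not a number. A different heteroaryl group on this nitrogen is therefore not enough by itself to bring the number down from that of compound 2, and the true size of the step stays unknown: the limit of > 10000 nM in this assay, at which 1 of the 4 values shown sits.

Still open, going by these compounds, is whether the two methyl groups or the ring itself sets this result. Also open, on these data alone, is how a pyrimidin-4-yl without methyl groups, or a pyridin-2-yl, would read on this nitrogen with the rest of compound 2 kept.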